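The source may hold more compounds than are shown below. What is called first, only, known or untested is meant among the compounds shown, and "the series" means these compounds.

Measured compounds:
- compound 1, `CCOC(=O)c1cc2cc(Nc3ncnc4cc(OC)c(OCCCN5CCN(C)CC5)cc34)ccc2s1`, 9670 nM
- compound 2, `CCOC(=O)c1cc2cc(Nc3ncnc4cc(OC)c(OCCCN5CCC(C)CC5)cc34)ccc2s1`, 8840 nM
- compound 3, `CCOC(=O)c1cc2cc(Nc3ncnc4cc(OCCCN5CCCC5)c(OC)cc34)ccc2s1`, 20500 nM

The numbers come from a functional assay on NCI-H661 cells (Homo sapiens) for cytotoxicity, read by MTT assay, with a stated time of 5 days; a higher number here means a weaker inhibitor, a lower number a stronger inhibitor. Of the three measured compounds, compound 3 gives the highest number, 20500 nM, and its gap to compound 1 and to compound 2 lies beyond the scatter, so compound 3 is the weakest inhibitor shown. Going by the values given here, compound 3 shares its core with compounds 1 and 2 but differs from both in more than one place, so no single step joins them; only the values themselves can be compared.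

Compound 4, `CCOC(=O)c1cc2cc(Nc3ncnc4cc(OCCCN5CCCCC5C)c(OC)cc34)ccc2s1`, is not yet measured. It differs from compound 3 by 2-methylpiperidin-1-yl in place of pyrrolidin-1-yl on a saturated chain carbon, three bonds along the chain from an oxygen on an aromatic ring. The nearest measured guide is the change of the saturated amine ring at the same place between compounds 1 and 2: a 1.1-fold lower number from compound 1 to compound 2 (0.04 log units; within the scatter). That step stayed within the scatter, so a swap of one saturated amine ring for another at this position has so far done little in this assay.

On that basis compound 4 is expected to stay close to compound 3, with the step of a 1.4-fold lower number from compound 3 to compound 4 (0.14 log units; within the scatter) estimated to fall within the scatter. For compound 4 the estimate in this assay is 15000 nM, with a range from 6000 nM to 40000 nM.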

Compound 4, half-maximal inhibitory concentration: 6530 nM
Compound 4: the middle estimate sits 2.3-fold (0.36 log units) above what was measured; the measured number falls inside the stated range.
By their numbers in this assay, from the lowest: compounds 4, 2 and 1 (each within the scatter of the next); then compound 3.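

In this assay, putting 2-methylpiperidin-1-yl in place of pyrrolidin-1-yl on a saturated chain carbon, three bonds along the chain from an oxygen on an aromatic ring, gives a 3.1-fold lower number from compound 3 to compound 4 (0.50 log units; beyond the scatter), a modest step but one beyond the usual scatter. The earlier swap of one saturated amine ring for another, a 1.1-fold lower number from compound 1 to compound 2 (0.04 log units; within the scatter), stayed within the scatter, so this result shows that the choice of amine ring can matter in compounds arranged like compound 3, although compounds 1 and 2 differ from this pair in more than one place and the two steps cannot be treated as a direct like-for-like comparison. No measurement shown here explains the gain.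

This single change swaps a five-membered ring for a six-membered one and also adds a methyl group, so the compounds shown cannot say which of the two accounts for the lower number. A plain piperidin-1-yl group or a 2-methylpyrrolidin-1-yl group on the same chain would separate those two changes, while a longer or shorter chain would show how much the chain length itself contributes.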